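From isopropyl to cyclopentyl on a shared core

The source may hold more compounds than are shown below. What is called first, only, known or untested is meant among the compounds shown, and "the series" means these compounds.

In a functional assay on FaDu cells (Homo sapiens) for cytotoxicity, read by MTT assay, with a stated time of 72 h (a lower number here means that less compound is tolerated, a higher number that more compound is tolerated), compound 1 `COc1ncc(NC(=O)C(=O)c2cn(C(C)C)c3ccccc23)cn1` gives 171 nM and compound 2 `COc1ccc(NC(=O)C(=O)c2cn(C(C)C)c3ccccc23)cn1` gives 85 nM. Placing 6-methoxypyridin-3-yl where 2-methoxypyrimidin-5-yl stood on the amide-type nitrogen makes a 2.0-fold lower number from compound 1 to compound 2 (0.30 log units; within the scatter), so compound 2 stands level with compound 1, and these two are the only true numbers so far. Compound 3 `COc1ccc(NC(=O)C(=O)c2cn(C(C)C)c3c(OC)cccc23)cn1` reads > 10000 nM, which is a limit of the assay and not a number. Its methoxy in place of hydrogen on an aromatic carbon gives an at least 110-fold higher number from compound 2 to compound 3 (2.07 log units; beyond the scatter).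

Compound 4 `COc1ccc(NC(=O)C(=O)c2cn(C3CCCC3)c3ccccc23)cn1` changes a different place: cyclopentyl in place of isopropyl on an aromatic nitrogen. Neither measured step touches that aromatic nitrogen, so neither serves as a direct guide. The small step of a 2.0-fold lower number from compound 1 to compound 2 (0.30 log units; within the scatter) offers little on this point, while the large step of an at least 110-fold higher number from compound 2 to compound 3 (2.07 log units; beyond the scatter) is a warning that one change on the core can matter greatly. No shift beyond the scatter is the expected outcome, with a 1.2-fold higher number from compound 2 to compound 4 (0.07 log units; within the scatter) as the estimated step, held loosely and with a wide range. For compound 4 the estimate is 100 nM, with an expected range from 25 nM to 500 nM.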

Compound 4, concentration lethal to 50% of the cells: 370 nM
Beside the measured number, compound 4's estimate is 3.7-fold (0.57 log units) below it; the range from low to high includes it.
By their numbers in this assay, from the lowest: compounds 2 and 1 (each within the scatter of the next); then compound 4. At a limit, above all of these: compound 3.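

The aromatic nitrogen of the shared core turns out to be a place where the choice of group counts in this assay: a 4.4-fold higher number from compound 2 to compound 4 (0.64 log units; beyond the scatter). Among the compounds shown, a change on an aromatic carbon had already moved the number beyond the scatter, and this modest step adds a second place on the core, with cyclopentyl, a five-membered ring of carbon only, replacing isopropyl, which has no ring. Nothing measured here bears on why the number moves with this change.

As far as these compounds go, one pair cannot separate the effect of the ring from that of the added carbons, so it stays open where an open chain such as n-butyl or a smaller ring such as cyclopropyl on that nitrogen would fall. Where a chain ending in an amine would fall is equally open.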